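The compounds below may be only part of what the source reports. "The series", "measured", "known", "first", "only" and "open" are said of these compounds alone.

Compound 2 `Cc1ccc(S(=O)(=O)c2c[nH]cc2S(=O)(=O)CC2=NCCO2)cc1` gives 78.5% in a functional assay for inhibition, tested at 100 uM; on this read-out lower numbers stand for less inhibition and higher numbers for more inhibition at the one concentration tested (going by the name of the read-out). Going by the values given here, that is the higher of the two numbers measured so far; compound 1 `Cc1ccc(S(=O)(=O)/C=C/S(=O)(=O)CC2=NCCS2)cc1` gives 21.7% in this assay, well beyond the scatter of repeated measurements. Compound 3 `O=S(=O)(CC1=NCCO1)c1c[nH]cc1S(=O)(=O)c1ccc(Cl)cc1` has not yet been measured. It differs from compound 2 in one place: chloro in place of methyl on an aromatic carbon. Among the compounds with values here, no measured pair shows what such a change does here, so the expected step from compound 2 to compound 3 is a number 6.5 percentage points lower from compound 2 to compound 3 (within the scatter), not beyond the scatter in either direction. Compound 3 is therefore estimated at 72%, somewhere between 50% and 90%.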

Compound 3, a percentage reported as inhibition, at one concentration (the size of the read-out at that concentration, not a potency): 92.1%
For compound 3 the middle estimate is 20.1 percentage points below the measured one; measured number above the stated range.
By their numbers in this assay, from the lowest: compound 1; then compound 2; then compound 3.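

Putting chloro in place of methyl on this aromatic carbon changes the result in this assay by a number 13.6 percentage points higher from compound 2 to compound 3 (beyond the scatter) as the 4-methylphenyl becomes 4-chlorophenyl. This position therefore responds to the exchange of a single heavy atom, even though neither group carries a hydrogen-bond donor or acceptor. Nothing available explains why this exchange raises the number.

From the compounds shown here alone, whether other groups at this position, such as fluoro, methoxy or an amine, would go higher or lower stays open. Also open, going by these compounds, is whether the same exchange would raise the number for compound 1, which has the same 4-methylphenyl group.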